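Chloro to amino on the shared core: outlook for compound 3

This account rests on a few compounds, and the source may have more. Where it says the series, first, only, none or still open, it means among the compounds named here.

Measured so far:
compound 1, `ClCc1ccccc1Cn1cnc2c(Cl)nc(Cl)nc21` — 890 nM
compound 2, `ClCc1ccc(Cn2cnc3nc(Cl)nc(Cl)c32)cc1` — 2750 nM

In a functional assay on CAKI-1 cells (Homo sapiens) for cytotoxicity, read by sulforhodamine B assay, with a stated time of 48 h (a higher number here means a weaker inhibitor of growth, a lower number a stronger inhibitor of growth), compound 1 gives 890 nM and holds the lowest of the two numbers. Within the data shown here, compound 2 gives 2750 nM in this assay, a higher number that lies beyond the usual scatter; no single-point step connects these two compounds, so only the two values themselves speak.

Compound 3, `Nc1nc(Cl)c2ncn(Cc3ccccc3CCl)c2n1`, keeps the core of compound 1 and differs in one place: amino in place of chloro on an aromatic carbon. Among the measured compounds shown here, no measured pair in this set carries that change, so its size is unknown here. Among the two compounds, a move away from compound 1 has so far gone toward a higher number, and a swap of chloro for amino is taken, as a working assumption, to sit in the same direction at modest size rather than within the scatter.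

Compound 3 is expected to give about 1800 nM in this assay, with a range from 600 nM to 6000 nM.

The estimated step of a 2.0-fold higher number from compound 1 to compound 3 (0.31 log units; beyond the scatter) is thus a mild rise in the number.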

Compound 3, concentration for total growth inhibition: 20400 nM
Compound 3: the middle estimate sits 11-fold (1.05 log units) below what was measured, outside the stated range (above it).
By their numbers in this assay, from the lowest: compound 1; then compound 2; then compound 3.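

In this assay, amino in place of chloro on an aromatic carbon, at the place between two ring nitrogen atoms, gives a 23-fold higher number from compound 1 to compound 3 (1.36 log units; beyond the scatter). Among these compounds, this is the only single-place step so far, and it is large and beyond the scatter, so this position is far from indifferent to what it carries. Among the compounds shown here, with the rest of compound 1 held constant, the swap alone moves the series toward a weaker inhibitor of growth, which the two-value comparison of the earlier compounds could not show. No measurement at hand bears on why the step is this size.

As far as these compounds go, it remains open whether the rise follows from the loss of chloro or the entry of amino, and hydrogen, a methoxy group or a methylamino group at the same place would help separate the two. Also open, from the compounds shown here alone, is whether the same swap carries a step of like size on the core of compound 2, and whether the other chloro group, meta to this place, tolerates an amine.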